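Swapping amino for hydroxy in a small series

The source may report more compounds than this note shows. Statements on the series, on what has been measured and on what is new or still open speak of the compounds shown alone.

In a functional assay on MDA-MB-231 cells (Homo sapiens) for inhibition, read by MTT assay, with a stated time of 48 h (on this read-out higher numbers stand for weaker inhibition and lower numbers for stronger inhibition), compound 3 `COc1cc(-c2nccn3cc(-c4ccc(N)cc4)nc23)cc(OC)c1OC` gives 294 nM and compound 1 `COc1cc(-c2nccn3cc(-c4ccc(F)cc4)nc23)cc(OC)c1OC` gives 401 nM, two values within the scatter of each other. Compound 2 `COc1cc(-c2nccn3cc(-c4ccc(C(F)(F)F)cc4)nc23)cc(OC)c1OC` returns only a limit of the assay, > 10000 nM. Compound 4 `COc1cc(-c2nccn3cc(-c4ccc(O)cc4)nc23)cc(OC)c1OC` carries hydroxy in place of amino on an aromatic carbon, para to a large group (hydroxy in place of amino on an aromatic carbon). Among the measured compounds shown here, three measured steps bear on this position. Trifluoromethyl in place of fluoro gave the large at least 24-fold higher number from compound 1 to compound 2 (1.39 log units; beyond the scatter), and amino in place of trifluoromethyl gave the large at least 34-fold lower number from compound 2 to compound 3 (1.53 log units; beyond the scatter). Amino in place of fluoro gave only a 1.4-fold lower number from compound 1 to compound 3 (0.13 log units; within the scatter), within the scatter, and this small step is taken as the closer guide. The expected change in this assay is therefore a 1.2-fold higher number from compound 3 to compound 4 (0.08 log units; within the scatter), none beyond the scatter. Compound 4 is estimated at 350 nM, with an expected range from 120 nM to 1200 nM.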

Compound 4, half-maximal inhibitory concentration: > 10000 nM
Compound 4 was reported as a limit; the forecaster's own chance of this, stated with the estimate: 5%; middle value at least 28-fold (1.45 log units) away from the limit.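

In this assay, among the compounds shown here, this position proves far less forgiving than the earlier compounds suggested: amino and hydroxy, each a single heavy atom with the same hydrogen-bond count, are not interchangeable, giving an at least 34-fold higher number from compound 3 to compound 4 (1.53 log units; beyond the scatter) and an at least 24-fold higher number from compound 1 to compound 4 (1.39 log units; beyond the scatter). Hydroxy therefore parts from fluoro and amino, and compound 4 joins compound 2 at an assay limit: the limit of > 10000 nM in this assay, at which 2 of the 4 values shown sit. With both values being limits, the step between these two compounds cannot be read.

On these data alone, how far compound 4 lies beyond its limit remains unknown. As far as these compounds go, whether a methylamino group or a carboxylic acid here would behave like amino or like hydroxy also remains open.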